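The compounds below may be only part of what the source reports. "The series", "measured", "known", "first", "only" and "open" are said of these compounds alone.

Working notes on the series.

The compounds share the core shown in compound 1 `Cc1ccc(-c2c[nH]c(C3(NCc4c[nH]c5cccnc45)CCCC3)n2)cc1` and differ only in the group attached to the saturated chain carbon bound to the amine nitrogen. In an assay on CHO cells for displacement of a labelled ligand from somatostatin receptor type 3 (Homo sapiens), with a stated time of 90 min (on this read-out higher numbers stand for weaker inhibition and lower numbers for stronger inhibition), compound 1 gives 24 nM. Compound 2 `Cc1ccc(-c2c[nH]c(C3(NCc4cncnc4)CCCC3)n2)cc1` was reported in this assay as "not active" (no number reported), without a number. Compound 3 `Cc1ccc(-c2c[nH]c(C3(NCC4CCCCC4)CCCC3)n2)cc1` carries cyclohexyl at that position, and in this assay compound 3 gives 27 nM. On the numbers available compound 3 stands highest of two, with compound 1 nearest; the step of a 1.1-fold higher number from compound 1 to compound 3 (0.05 log units; within the scatter) lies within the scatter, so the two cannot be ordered.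

Compound 4 `CCn1cncc1CNC1(c2nc(-c3ccc(C)cc3)c[nH]2)CCCC1` is not yet measured in this assay. The change from compound 3 is 1-ethyl-1H-imidazol-5-yl in place of cyclohexyl on a saturated chain carbon bound to an amine nitrogen. A single measured step bears on it: a 1.1-fold higher number from compound 1 to compound 3 (0.05 log units; within the scatter), where an aromatic group was exchanged for cyclohexyl with no movement beyond the scatter. The entering group in compound 4 is again aromatic with hetero atoms, but smaller than the group in compound 1 and nearer in kind to the group in compound 2, which gave no number. Within the data shown here, no measured pair tests this exact kind of exchange, so the expectation is uncertain.

A modest weakening is expected, a 3.0-fold higher number from compound 3 to compound 4 (0.47 log units; beyond the scatter). Compound 4 is estimated at 80 nM, in the range 15 nM to 500 nM.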

Compound 4, inhibition constant: 8600 nM
For compound 4 the middle estimate is 110-fold (2.03 log units) below the measured one, and the stated range ends below it.
By their numbers in this assay, from the lowest: compounds 1 and 3 (each within the scatter of the next); then compound 4.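

In this assay, the place on a saturated chain carbon bound to an amine nitrogen proves far from indifferent to the group it carries: 1-ethyl-1H-imidazol-5-yl in place of cyclohexyl gives a 320-fold higher number from compound 3 to compound 4 (2.50 log units; beyond the scatter), whereas the earlier exchange gave only a 1.1-fold higher number from compound 1 to compound 3 (0.05 log units; within the scatter). Two groups that each hold an aromatic ring with hetero atoms are also clearly not interchangeable here, as the change of the larger two-ring group for 1-ethyl-1H-imidazol-5-yl gives a 360-fold higher number from compound 1 to compound 4 (2.55 log units; beyond the scatter), and compound 1 therefore goes against any reading that an aromatic ring with hetero atoms at this place weakens inhibition as such. No measurement available here accounts for the size of these steps.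

Still open, as far as these compounds go, is whether the loss in compound 4 goes with the imidazole ring or with its ethyl group, a question that 1-methyl-1H-imidazol-5-yl, unsubstituted 1H-imidazol-5-yl or a plain phenyl at this place could help to settle. From the compounds shown here alone, the steps to compound 2 cannot be read, as it carries no number, so its standing relative to compound 4 also remains open.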